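Dimethoxyphenyl in place of chlorophenyl: expected growth inhibition

The source may report more compounds than this note shows. Statements on the series, on what has been measured and on what is new or still open speak of the compounds shown alone.

Measured in a functional assay on COLO 205 cells (Homo sapiens) for inhibition, read by sulforhodamine B assay (a higher number here means a weaker inhibitor of growth, a lower number a stronger inhibitor of growth), so far:
- compound 1 `COc1ccc(-c2ccc(-c3ccc(-c4nc5cc(C)ccc5[nH]4)cc3)cc2)cc1OC` gives 2320 nM
- compound 2 `CN(C)c1ccc(-c2ccc(-c3ccc(-c4nc5ccccc5[nH]4)cc3)cc2)cc1` gives 100000 nM
- compound 3 `Clc1cccc(-c2ccc(-c3ccc(-c4nc5ccccc5[nH]4)cc3)cc2)c1` gives 100000 nM

Compound 3 stands level with compound 2 at the top of these numbers, with compound 1 far lower. Next is compound 4 `COc1ccc(-c2ccc(-c3ccc(-c4nc5ccccc5[nH]4)cc3)cc2)cc1OC`, which differs from compound 3 as follows: 3,4-dimethoxyphenyl in place of 3-chlorophenyl on an aromatic carbon. Within the data shown here, the one measured step, no change at the digits printed from compound 2 to compound 3 (within the scatter), shows no change and gives no guide to size. Compound 1 carries the same 3,4-dimethoxyphenyl on a different core and gives 2320 nM, so a lower number is expected in this assay. The expected step is a 17-fold lower number from compound 3 to compound 4 (1.22 log units; beyond the scatter). For compound 4 the estimate is 6000 nM, with an expected range of 1500 nM to 40000 nM.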

Compound 4, concentration for 50% growth inhibition: 41200 nM
The estimate for compound 4 lay 6.9-fold (0.84 log units) below the measured number; the whole stated range lies below it.
By their numbers in this assay, from the lowest: compound 1; then compound 4; then compounds 2 and 3 (each within the scatter of the next).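

In this assay, 3,4-dimethoxyphenyl moves the number at this position on the shared core, where the 3-chlorophenyl and 4-(dimethylamino)phenyl groups sat level: a 2.4-fold lower number from compound 3 to compound 4 (0.39 log units; beyond the scatter) and a 2.4-fold lower number from compound 2 to compound 4 (0.39 log units; beyond the scatter), both modest. The change at the methyl place is large by comparison, an 18-fold higher number from compound 1 to compound 4 (1.25 log units; beyond the scatter), so removing that one methyl outweighs either swap of the aryl group. Nothing available explains these steps.

Open, as far as these compounds go, is whether the methyl gives a similar step alongside 3-chlorophenyl or 4-(dimethylamino)phenyl. Also open, from the compounds shown here alone, is how a methoxy, an amine or a carboxylic acid would compare at the methyl place.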